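Removing the nitrile from the most cytotoxic tetrazole analogue

The source may hold more compounds than are shown below. What is called first, only, known or untested is meant among the compounds shown, and "the series" means these compounds.

The shared core carries a thiazol-2-ylidene hydrazide whose acyl arm is joined through a sulfur to a small heteroaryl. Compound 1 `Cn1cnnc1SCC(=O)N/N=c1/scc(-c2ccc(C#N)cc2)n1-c1ccccc1` bears a 4-methyl-4H-1,2,4-triazol-3-yl there and in a functional assay on C6 cells (Rattus norvegicus) for cytotoxicity, read by MTT assay, with a stated time of 24 h, tested at 200 ug/mL (on this read-out higher numbers stand for a weaker effect at the one concentration tested and lower numbers for a stronger effect), compound 1 gives 52.6%. Compound 2 `Cn1nnnc1SCC(=O)N/N=c1/scc(-c2ccc(C#N)cc2)n1-c1ccccc1` carries a 1-methyl-1H-tetrazol-5-yl instead and gives 28.6%, the strongest effect of the three, as a number 24 percentage points lower from compound 1 to compound 2 (beyond the scatter) shows. Compound 3 `N#Cc1ccc(-c2cs/c(=N/NC(=O)CSc3nnnn3-c3ccccc3)n2-c2ccccc2)cc1`, with a 1-phenyl-1H-tetrazol-5-yl, gives 54%, so that a number 1.4 percentage points higher from compound 1 to compound 3 (within the scatter) and a number 25.4 percentage points higher from compound 2 to compound 3 (beyond the scatter).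

Compound 4 `Cn1nnnc1SCC(=O)N/N=c1/scc(-c2ccccc2)n1-c1ccccc1` differs from compound 2 only at the far end of the molecule: hydrogen in place of cyano on an aromatic carbon. Within the data shown here, none of the measured steps touches this position; all three move the heteroaryl on the sulfur or the substituent on its aromatic nitrogen, while the 4-cyanophenyl is kept throughout. Among the measured compounds shown here, there is therefore no measured step that bears on the change, and the expectation rests on compound 2 alone.

Compound 4 is thus expected to stay close to compound 2, with a step of a number 6.4 percentage points higher from compound 2 to compound 4 (within the scatter) that lies within the scatter. The estimate for compound 4 is 35%, in a range from 18% to 55%.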

Compound 4, a percentage reported as activity, at one concentration (the size of the read-out at that concentration, not a potency): 26.8%
Compound 4: middle estimate off by 8.2 percentage points, on the high side; the measured number falls inside the stated range.
By their numbers in this assay, from the lowest: compounds 4 and 2 (each within the scatter of the next); then compounds 1 and 3 (each within the scatter of the next).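

Among these compounds, this is the first measured step at the aromatic carbon para to a large group, since the earlier comparisons varied only the heteroaryl on the sulfur and the substituent on its aromatic nitrogen. In this assay, going from 4-cyanophenyl to phenyl gives a number 1.8 percentage points lower from compound 2 to compound 4 (within the scatter), so with the 1-methyl-1H-tetrazol-5-yl kept in place, the cyano group, with its 2 heavy atoms and 1 hydrogen-bond acceptor, can give way to hydrogen without a difference beyond the usual scatter of this read-out. Nothing shown here offers an explanation for this result.

The compounds shown leave open whether the cyano group can be dispensed with in the same way when the sulfur carries the 4-methyl-4H-1,2,4-triazol-3-yl or the 1-phenyl-1H-tetrazol-5-yl, since this single pair holds only the 1-methyl-1H-tetrazol-5-yl. They also leave open whether other groups on that aromatic carbon, such as an amine, a carboxylic acid, a methoxy group or a longer alkyl chain, would stay within the scatter of hydrogen and cyano or move the read-out beyond it.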